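Hydantoin anilides: chlorophenyl in place of phenylethenyl

A few compounds are considered here, and "the series" means these few. Any claim that something is new, unique, unknown or untested is made for them only; others in the source may bear on it.

Measured so far:
compound 1 `O=C(CN1C(=O)N/C(=C\C=C\c2ccccc2)C1=O)Nc1ccc(Cl)cc1` — < 100000 nM
compound 2 `O=C(CN1C(=O)N/C(=C\c2ccc(Cl)cc2)C1=O)Nc1ccccc1C(F)(F)F` — 12600 nM

In a functional assay on SR cells (Homo sapiens) for inhibition, read by sulforhodamine B assay, with a stated time of 48 h (a lower number here means a stronger inhibitor of growth, a higher number a weaker inhibitor of growth), compound 1 gives only < 100000 nM, which is a limit of the assay and not a number. Compound 2 gives 12600 nM in this assay. The pair shares the core and the amide, and differs at two places, so their two values are all that can be read. Compound 3 `O=C(CN1C(=O)N/C(=C\c2ccc(Cl)cc2)C1=O)Nc1ccc(Cl)cc1` carries 4-chlorophenyl in place of 2-phenylethenyl on a double-bonded chain carbon bound to a double-bonded ring carbon relative to compound 1. Compound 1 stands at the limit of < 100000 nM in this assay, at which 1 of the 2 values shown sits, so only the chlorophenyl-bearing compound 2 offers a number in this assay. Compound 3 is expected near 15000 nM, within 4000 nM to 60000 nM. The expected step from compound 1 to compound 3 is a step that the limit leaves unreadable from compound 1 to compound 3, its direction uncertain since compound 1 is a limit.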

Compound 3, concentration for total growth inhibition: 33900 nM
Compound 3: middle estimate off by 2.3-fold (0.35 log units), on the low side, within the range that was stated.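

The step from compound 1 to compound 3 cannot be read, because the value of compound 1 is a limit and not a number: the limit of < 100000 nM in this assay, at which 1 of the 3 values shown sits.

In this assay the compounds shown leave open how far 4-chlorophenyl in place of 2-phenylethenyl shifts growth inhibition, and in which direction.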